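The source may hold more compounds than are shown below. What is called first, only, known or untested is meant among the compounds shown, and "the series" means these compounds.

In a functional assay on cells (Cancer cell lines, Homo sapiens) for inhibition (a lower number here means a stronger inhibitor of growth, a higher number a weaker inhibitor of growth), compound 1 (`N=C(N)N/N=C/c1c(-c2cc(Cl)sc2Cl)nc2n1CCS2`) gives 17400 nM, compound 2 (`Cc1cn2c(/C=N/NC(=N)N)c(-c3cccs3)nc2s1`) gives 11700 nM and compound 3 (`Cc1cc(-c2nc3n(c2/C=N/NC(=N)N)CCS3)c(C)s1`) gives 34700 nM. Compound 3 thus sits within the scatter of compound 1 and, beyond the scatter, above compound 2. Compound 4 (`N=C(N)N/N=C/c1c(-c2cccs2)nc2n1CCS2`) differs from compound 3 as follows: thiophen-2-yl in place of 2,5-dimethylthiophen-3-yl on an aromatic carbon. Within the data shown here, the one measured step at this place, a 2.0-fold higher number from compound 1 to compound 3 (0.30 log units; within the scatter), offers little guidance on the swap. Compound 2 bears thiophen-2-yl on a different core and gives 11700 nM, which hints at a lower number. A small move downward in this assay is therefore expected, near the edge of the scatter. The expected change is a 1.7-fold lower number from compound 3 to compound 4 (0.24 log units; within the scatter). Compound 4 is estimated at 20000 nM, with an expected range of 9000 nM to 42000 nM.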

Compound 4, concentration for total growth inhibition: 39800 nM
Compound 4: the middle estimate sits 2.0-fold (0.30 log units) below what was measured; measured number inside the range.
By their numbers in this assay, from the lowest: compounds 2, 1, 3 and 4 (each within the scatter of the next, the first and the last beyond it).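

In this assay thiophen-2-yl in place of 2,5-dimethylthiophen-3-yl gives a 1.1-fold higher number from compound 3 to compound 4 (0.06 log units; within the scatter) and so does not separate these two groups at this position. Set against 2,5-dichlorothiophen-3-yl, the same group gives a 2.3-fold higher number from compound 1 to compound 4 (0.36 log units; beyond the scatter) as the first step at this place beyond the scatter, though a modest one. No supporting evidence bears on either step.

Still open, as far as these compounds go, is whether a group other than a thiophene at this aromatic carbon, such as phenyl or an aminomethyl group, would move the number further in either direction.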